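This account rests on a few compounds, and the source may have more. Where it says the series, first, only, none or still open, it means among the compounds named here.

Measured so far:
compound 1, `Cc1cccc(NS(=O)(=O)c2ccc(N3CCNC3=O)cc2)c1`: 190 nM
compound 2, `COc1ccc(NS(=O)(=O)c2ccc(N3CCNC3=O)cc2)cc1OC`: 610 nM

Both were run in a functional assay on MCF7 cells (Homo sapiens) for antiproliferative activity, read by sulforhodamine B assay, with a stated time of 48 h; on this read-out lower numbers stand for stronger inhibition and higher numbers for weaker inhibition. Compound 1 gives the lower of the two numbers; compound 2 sits well above it, and the gap between them is beyond the usual scatter, so compound 1 is the stronger of this pair. Within the data shown here, no step between two measured compounds that differ in one place is available, so nothing on the effect of a single change has yet been seen.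

The next compound is compound 3, `Cc1ccc(NS(=O)(=O)c2ccc(N3CCNC3=O)cc2)c(C)c1`. It differs from compound 1 in one place: 2,4-dimethylphenyl in place of 3-methylphenyl on a sulfonamide nitrogen. The shared core is kept; the change is 2,4-dimethylphenyl in place of 3-methylphenyl on a sulfonamide nitrogen. Among the measured compounds shown here, with no comparable step on record, the expected step in this assay is small, in either direction, and likely not beyond the scatter. Compound 3 is estimated at 260 nM, with a range from 100 nM to 700 nM, which means an expected step of a 1.4-fold higher number from compound 1 to compound 3 (0.14 log units; within the scatter).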

Compound 3, half-maximal inhibitory concentration: 230 nM
Estimate against measurement, compound 3: 1.1-fold (0.05 log units) above, and the stated range covers the measured number.
By their numbers in this assay, from the lowest: compounds 1 and 3 (each within the scatter of the next); then compound 2.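

In this assay, among these compounds, 2,4-dimethylphenyl in place of 3-methylphenyl on a sulfonamide nitrogen gives a 1.2-fold higher number from compound 1 to compound 3 (0.08 log units; within the scatter) and is the first single-place step available. The sulfonamide nitrogen therefore accepts this second aryl group, and the values of the pair cannot be told apart from repeat measurements. No measured information bears on this result.

From the compounds shown here alone, what a carboxylic acid or an amine on this phenyl ring would do remains open, as does a longer chain such as propyl in place of a methyl group. A single step also leaves open whether any substituent at this position moves the number beyond the scatter.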